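The source may report more compounds than this note shows. Statements on the series, on what has been measured and on what is new or still open speak of the compounds shown alone.

Values in a functional assay on A549 cells (Homo sapiens) for antiproliferative activity, with a stated time of 5 days; on this read-out lower numbers stand for stronger inhibition and higher numbers for weaker inhibition:
- compound 1 `CC1OC2(C=CC(=O)C=C2)N(c2nc(-c3ccc4ccccc4c3)nn2-c2ccc3ccccc3c2)C1=O`: 300 nM
- compound 2 `CC1CN(c2nc(-c3ccc4ccccc4c3)nn2-c2ccccc2)C2(C=CC(=O)C=C2)O1`: 320 nM
- compound 3 `CC1OC2(C=CC(=O)C=C2)N(c2nc(-c3ccc4ccccc4c3)nn2-c2ccccc2)C1=O`: 310 nM

The three values lie within the scatter of each other, so compound 3 holds no distinct rank. Compound 4 `CC1OC2(C=CC(=O)C=C2)N(c2nc(-c3cccc4ccccc34)nn2-c2ccccc2)C1=O` differs from compound 3 as follows: naphthalen-1-yl in place of naphthalen-2-yl on an aromatic carbon. This puts naphthalen-1-yl in place of naphthalen-2-yl on an aromatic carbon. Among the measured compounds shown here, the one measured step, a 1.0-fold higher number from compound 1 to compound 3 (0.01 log units; within the scatter), concerns an aromatic nitrogen rather than this carbon, so it bears only indirectly. For the measured compounds named here, no measured step changes the group at this place. With that single step as a guide, no change beyond the scatter is expected in this assay. The expected step is a 1.2-fold higher number from compound 3 to compound 4 (0.09 log units; within the scatter). For compound 4 the estimated value is 380 nM, with an expected range of 150 nM to 1000 nM.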

Compound 4, half-maximal inhibitory concentration: 180 nM
Beside the measured number, compound 4's estimate is 2.1-fold (0.32 log units) above it, within the range that was stated.
By their numbers in this assay, from the lowest: compounds 4, 1, 3 and 2 (each within the scatter of the next).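

Until now this aromatic carbon carried only naphthalen-2-yl. In this assay, naphthalen-1-yl in place of naphthalen-2-yl gives a 1.7-fold lower number from compound 3 to compound 4 (0.24 log units; within the scatter), so moving the attachment point of the naphthalene on this carbon leaves the value within the scatter. No supporting data bear on this result.

As far as these compounds go, whether an amine or a carboxylic acid on this carbon would hold the value stays open. Also open, from the compounds shown here alone, is whether naphthalen-1-yl gives a similar result with the core of compound 2.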